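The compounds below may be only part of what the source reports. "The series", "measured", "known", "first", "only" and "open" are said of these compounds alone.

Compounds measured in a functional assay on U-251 cells (Homo sapiens) for inhibition, read by sulforhodamine B assay, with a stated time of 48 h; a lower number here means a stronger inhibitor of growth, a higher number a weaker inhibitor of growth:
compound 1 `Ic1ccc(Cn2cc(CCCOc3cccc4cccnc34)nn2)cc1`, > 250 ug/mL;
compound 2 `Brc1ccc(Cn2cc(CCCOc3cccc4cccnc34)nn2)cc1`, 8.4 ug/mL;
compound 3 `c1ccc(Cn2cc(CCCOc3cccc4cccnc34)nn2)cc1`, 25.2 ug/mL.

Compound 1 stands at the limit of > 250 ug/mL in this assay, at which 1 of the 3 values shown sits, a limit of the assay rather than a number. Compound 4 `c1cncc(CCCn2cc(CCCOc3cccc4cccnc34)nn2)c1` differs from compound 1 by 2-(pyridin-3-yl)ethyl in place of 4-iodophenyl on a saturated chain carbon bound to an aromatic nitrogen. Among the compounds with values here, two measured steps bear on this change, both removing the iodo: an at least 29-fold lower number from compound 1 to compound 2 (1.47 log units; beyond the scatter) and an at least 9.9-fold lower number from compound 1 to compound 3 (0.99 log units; beyond the scatter). Within the data shown here, both gave lower numbers, so a lower number is expected for compound 4 as well, though the entering group has no measured counterpart here. The expected step is an at least 6.2-fold lower number from compound 1 to compound 4 (0.79 log units; beyond the scatter). Compound 4 is therefore estimated at 40 ug/mL, with a range from 10 ug/mL to 250 ug/mL.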

Compound 4, concentration for 50% growth inhibition: 25.1 ug/mL
Compound 4: middle estimate off by 1.6-fold (0.20 log units), on the high side, within the range that was stated.
By their numbers in this assay, from the lowest: compound 2; then compounds 4 and 3 (each within the scatter of the next). At a limit, above all of these: compound 1.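

In this assay, 2-(pyridin-3-yl)ethyl shows that the place on a saturated chain carbon bound to an aromatic nitrogen accepts a group other than a substituted or plain phenyl, with compound 3 and compound 4 within the scatter of each other: a 1.0-fold lower number from compound 3 to compound 4 (0.00 log units; within the scatter). Replacing 4-bromophenyl with this group gives a 3.0-fold higher number from compound 2 to compound 4 (0.48 log units; beyond the scatter). Compound 1 is held at a limit, so an at least 9.9-fold lower number from compound 1 to compound 4 (0.99 log units; beyond the scatter) gives only a bound: the limit of > 250 ug/mL in this assay, at which 1 of the 4 values shown sits.

The compounds shown leave open where 4-chlorophenyl or 4-fluorophenyl would fall. They also leave open whether an amine in place of the pyridine ring would match compound 4.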